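The source may report more compounds than this note shows. Statements on the series, on what has been measured and on what is new or still open speak of the compounds shown alone.

Measured in a functional assay on MCF7 cells (Homo sapiens) for cytotoxicity, read by MTT assay, with a stated time of 48 h; a higher number here means a weaker inhibitor, a lower number a stronger inhibitor:
compound 1 `COc1cc(-c2nnc3n2NC(c2cccs2)C(C(=O)c2ccccc2)S3)cc(OC)c1OC` gives > 100000 nM
compound 2 `COc1cc(-c2nnc3n2NC(c2ccco2)C(C(=O)c2ccccc2)S3)cc(OC)c1OC` gives 39800 nM

Compound 1 stands at a limit of this assay, its value being only the limit of > 100000 nM in this assay, at which 1 of the 2 values shown sits, rather than a number. Among the compounds with values here, the one measured step, an at least 2.5-fold lower number from compound 1 to compound 2 (0.40 log units; beyond the scatter), concerns an exchange on a saturated ring carbon and says nothing about the benzoyl side of the shared core. Compound 3 `COc1ccc(C(=O)C2Sc3nnc(-c4cc(OC)c(OC)c(OC)c4)n3NC2c2cccs2)cc1` differs from compound 1 by methoxy in place of hydrogen on an aromatic carbon. Within the data shown here, no measured step touches this place, so nothing in the numbers points to a change in either direction, and with compound 1 already at the limit any movement toward a weaker inhibitor could not be seen at all. The step of a number no higher from compound 1 to compound 3 (the limit leaves the size open) is therefore expected to stay within the scatter. Compound 3 is estimated at 100000 nM in this assay, with a range from 30000 nM to 300000 nM, and most likely again only a limit would be reported.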

Compound 3, half-maximal inhibitory concentration: 49500 nM
Compound 3: the middle estimate sits 2.0-fold (0.31 log units) above what was measured, within the range that was stated.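

In this assay, methoxy in place of hydrogen on an aromatic carbon, para to a large group, gives an at least 2.0-fold lower number from compound 1 to compound 3 (0.30 log units; that floor lies within the scatter). Within the data shown here, this is the first reading from the benzoyl side of the shared core, and it shows that this position can be changed with a measurable number as the result, since compound 3 gives 49500 nM. Compound 1 has only a limit, so the true size of the step cannot be read and the printed floor is all that can be said of it: the limit of > 100000 nM in this assay, at which 1 of the 3 values shown sits.

Whether the lower number belongs to methoxy itself remains open, as the compounds shown do not include a hydroxyl, an amine or a longer chain such as ethoxy at this place. Also open, from the compounds shown here alone, is how 4-methoxyphenyl would behave on the core of compound 2, with furan-2-yl in place of thiophen-2-yl.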